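Ring-nitrogen substituent and sigma-1 binding in the benzhydrylthioethylamine series

The source may report more compounds than this note shows. Statements on the series, on what has been measured and on what is new or still open speak of the compounds shown alone.

Compound 1 `Fc1ccc(C(SCCNC2CCN(Cc3ccc(Cl)cc3)CC2)c2ccc(F)cc2)cc1` and compound 2 `Fc1ccc(C(SCCNC2CCN(Cc3cc4ccccc4o3)CC2)c2ccc(F)cc2)cc1` share the same core and differ only in the group on the amine nitrogen in the ring. In an assay on membranes from Cortex for displacement of a labelled ligand from Sigma non-opioid intracellular receptor 1 (Cavia porcellus), read by scintillation counting, with a stated time of 120 min (a higher number here means a weaker inhibitor, a lower number a stronger inhibitor), compound 1 gives 45.5 nM, and compound 2 gives 205 nM. Among the compounds with values here, the single step between them, a 4.5-fold higher number from compound 1 to compound 2 (0.65 log units; beyond the scatter), places compound 2 at the highest of the two numbers measured so far, with compound 1 as its nearest neighbour.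

Compound 3 `O=C(C1CC1)N1CCC(NCCSC(c2ccc(F)cc2)c2ccc(F)cc2)CC1` has not yet been measured in this assay. Relative to compound 2 the change is cyclopropylcarbonyl in place of (1-benzofuran-2-yl)methyl on an amine nitrogen in a ring. Within the data shown here, the only measured step bearing on this position is the one from compound 1 to compound 2, which was of modest size and beyond the scatter; it shows that exchanging groups on this nitrogen moves the number. Among the measured compounds shown here, the present change is of a different kind, and no measured pair covers it. The step of a 2.9-fold higher number from compound 2 to compound 3 (0.47 log units; beyond the scatter) is therefore expected to be upward and beyond the scatter, with wide uncertainty. For compound 3 the estimate is 600 nM, within 120 nM to 3000 nM.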

Compound 3, inhibition constant: 46.4 nM
For compound 3 the middle estimate is 13-fold (1.11 log units) above the measured one; measured number below the stated range.
By their numbers in this assay, from the lowest: compounds 1 and 3 (each within the scatter of the next); then compound 2.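

The group on this amine nitrogen in a ring need not be aromatic for a low number in this assay: the change to cyclopropylcarbonyl, with 5 heavy atoms and a three-membered non-aromatic ring in place of 10 heavy atoms and two aromatic rings, gives a 4.4-fold lower number from compound 2 to compound 3 (0.65 log units; beyond the scatter) and so reverses the loss seen with the (1-benzofuran-2-yl)methyl group. With a 1.0-fold higher number from compound 1 to compound 3 (0.01 log units; within the scatter) the cyclopropylcarbonyl and 4-chlorobenzyl groups cannot be told apart, although only the latter carries an aromatic ring, so across these three compounds the presence of an aromatic ring does not sort the numbers, with compound 1 and compound 2 both carrying one and lying apart. No measurement at hand accounts for these differences.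

Still open, going by these compounds, is whether the carbonyl or the three-membered ring matters more here, a question that a cyclopropylmethyl group or an acetyl group on this nitrogen would address. It is also unclear how far the tolerance at this position extends, for instance to a cyclohexylcarbonyl group, a plain benzoyl group or a free ring amine.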